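Hydrogen in place of bromo on an aromatic carbon

This account rests on a few compounds, and the source may have more. Where it says the series, first, only, none or still open, it means among the compounds named here.

Of the compounds shown here, three with the same core have been measured so far. Compound 1 (`Clc1ccc(-c2nnc(SCCCN3CCN(c4nc5ccccc5o4)CC3)o2)cc1`) gives 121000 nM in a functional assay on HepG2 cells (Homo sapiens) for inhibition, read by MTT assay, with a stated time of 72 h (on this read-out higher numbers stand for weaker inhibition and lower numbers for stronger inhibition), while compound 2 (`Fc1ccc(-c2nnc(SCCCN3CCN(c4nc5ccccc5o4)CC3)o2)cc1`) gives 83800 nM and compound 3 (`Brc1ccc(-c2nnc(SCCCN3CCN(c4nc5ccccc5o4)CC3)o2)cc1`) gives 67500 nM on the same read-out. Compound 3 stands within the scatter of both others, with a 1.8-fold lower number from compound 1 to compound 3 (0.25 log units; within the scatter) and a 1.2-fold lower number from compound 2 to compound 3 (0.09 log units; within the scatter) as its two steps. Compound 4 (`c1ccc(-c2nnc(SCCCN3CCN(c4nc5ccccc5o4)CC3)o2)cc1`) has hydrogen in place of bromo on an aromatic carbon, para to a large group (hydrogen in place of bromo on an aromatic carbon). For the measured compounds named here, the steps that bear on this only swap one halogen for another, namely a 1.4-fold lower number from compound 1 to compound 2 (0.16 log units; within the scatter) together with the two above, and none of them leaves the scatter. Going by the values given here, no measured step removes the halogen altogether, so the expectation is an extrapolation. In this assay no step beyond the scatter is expected, and the data favour no direction. The estimated step is a 1.3-fold higher number from compound 3 to compound 4 (0.12 log units; within the scatter) and it stays small. Compound 4 is expected at 90000 nM with an estimated range from 45000 nM to 170000 nM as a working figure.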

Compound 4, half-maximal inhibitory concentration: 102000 nM
Beside the measured number, compound 4's estimate is 1.1-fold (0.05 log units) below it; measured number inside the range.
By their numbers in this assay, from the lowest: compounds 3, 2, 4 and 1 (each within the scatter of the next).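

With hydrogen in the place of the halogen, the change from 4-bromophenyl to phenyl gives a 1.5-fold higher number from compound 3 to compound 4 (0.18 log units; within the scatter) in this assay, while the other two replacements give a 1.2-fold higher number from compound 2 to compound 4 (0.09 log units; within the scatter) and a 1.2-fold lower number from compound 1 to compound 4 (0.07 log units; within the scatter). The earlier compounds shown here compared only one halogen with another, whereas these steps show that, on this aromatic carbon para to a large group, having no halogen at all cannot be told apart from having fluoro, chloro or bromo. Nothing available accounts for this flat result.

From the compounds shown here alone, it remains open whether a group of another kind at this place, such as an amine, a carboxylic acid or a methoxy group, would give a step beyond the scatter. Going by these compounds, it is also open whether the same holds with a longer chain on the ring.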